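This account rests on a few compounds, and the source may have more. Where it says the series, first, only, none or still open, it means among the compounds named here.

Measured so far:
compound 1 `O=C1C(NC2CC2)=CC(=O)c2c1nc1n2[C@H]2OC[C@@H](O)[C@H]2OC1` — > 16000 nM
compound 2 `O=C1C=C(Nc2ccccc2)C(=O)c2c1nc1n2[C@H]2OC[C@@H](O)[C@H]2OC1` — > 4000 nM
compound 3 `O=C1C=C(Nc2cccc(Cl)c2)C(=O)c2c1nc1n2[C@H]2OC[C@@H](O)[C@H]2OC1` — 4720 nM

In a functional assay on MCF7 cells (Homo sapiens) for inhibition, read by sulforhodamine B assay (on this read-out lower numbers stand for stronger inhibition and higher numbers for weaker inhibition), compound 1 gives only a limit, > 16000 nM, so its place is not fixed by a number. Compound 2 likewise gives only a limit in this assay, > 4000 nM. Within the data shown here, compound 3 is the one member with a number, 4720 nM. Among the measured compounds shown here, the single change with two measured ends runs from compound 2 to compound 3, a step that the limit leaves unreadable from compound 2 to compound 3; its size cannot be read because one end sits at the limit of > 4000 nM in this assay, at which 1 of the 3 values shown sits.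

Compound 4 `O=C1C(NCc2ccccc2)=CC(=O)c2c1nc1n2[C@H]2OC[C@@H](O)[C@H]2OC1` is not yet measured. It differs from compound 1 by benzyl in place of cyclopropyl on an amine nitrogen. For the measured compounds named here, no measured pair covers this change, so nothing bears on it directly. Going by the values given here, what is known is that compound 1 sits at the limit of > 16000 nM in this assay, at which 1 of the 3 values shown sits, and that the one numbered value in the set, from compound 3, is not far from the limits.

The expectation for compound 4 is therefore weak inhibition, with a step of an at least 2.0-fold lower number from compound 1 to compound 4 (0.30 log units; that floor lies within the scatter) from compound 1, of unreadable direction since compound 1 is only a limit. The estimate for compound 4 in this assay is 8000 nM, with a range of 2500 nM to 30000 nM, and a fair chance that only a limit is reported.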

Compound 4, half-maximal inhibitory concentration: > 8000 nM
Compound 4 was reported as a limit; the forecaster's own chance of this, stated with the estimate: 35%; the middle value lies on the limit itself.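

In this assay compound 4 gives only a limit, > 8000 nM. Compound 1 likewise gives only a limit, > 16000 nM. No step can be read between compound 1 and compound 4. The compounds shown leave open whether benzyl in place of cyclopropyl on an amine nitrogen changes inhibition at all, and if so, in which direction and how far.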